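The source may report more compounds than this note shows. Statements on the series, on what has been measured and on what is new or still open speak of the compounds shown alone.

Within the data shown here, compound 2 `COc1cc2ccc(C(O)(c3nc[nH]n3)C(C)C)cc2cc1OC` gives the higher of the two numbers known so far in an assay for inhibition of steroid 17-alpha-hydroxylase/17,20 lyase (Rattus norvegicus), read by LC-MS, using microsomes; a higher number here means a weaker inhibitor, a lower number a stronger inhibitor: compound 2 gives 7100 nM, while compound 1 `COc1cc2ccc(C(O)(c3cc[nH]n3)C(C)C)cc2cc1OC` gives 1600 nM. Among the measured compounds shown here, the one measured step, a 4.4-fold higher number from compound 1 to compound 2 (0.65 log units; beyond the scatter), shows that exchanging one five-membered aromatic ring for another on the saturated chain carbon bearing the hydroxyl can move the read-out by a modest amount that is still clearly beyond the scatter.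

Compound 3 `COc1cc2ccc(C(O)(c3cnco3)C(C)C)cc2cc1OC` is the next member, and it differs from compound 2 in the same place: 1,3-oxazol-5-yl in place of 1H-1,2,4-triazol-3-yl on a saturated chain carbon bound to an aromatic carbon, an oxygen on a saturated carbon and a saturated chain carbon. For the measured compounds named here, no measured step covers a triazole-to-oxazole exchange, so the only guide is the size of the pyrazole-to-triazole step. That step suggests a change of a size comparable to a 4.4-fold higher number from compound 1 to compound 2 (0.65 log units; beyond the scatter) in either direction is plausible, with no firm basis for picking a direction beyond the scatter.

Taking the midpoint between the two known numbers as the most likely outcome, compound 3 is expected to give 3000 nM in this assay, with a range from 800 nM to 12000 nM, which amounts to an expected step of a 2.4-fold lower number from compound 2 to compound 3 (0.37 log units; beyond the scatter).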

Compound 3, half-maximal inhibitory concentration: 86 nM
The estimate for compound 3 lay 35-fold (1.54 log units) above the measured number, outside the stated range (below it).
By their numbers in this assay, from the lowest: compound 3; then compound 1; then compound 2.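

At this position, on a saturated chain carbon bound to an aromatic carbon, an oxygen on a saturated carbon and a saturated chain carbon, the choice of five-membered aromatic ring can matter far more than the first exchange suggested: in this assay, 1,3-oxazol-5-yl gives an 83-fold lower number from compound 2 to compound 3 (1.92 log units; beyond the scatter) and a 19-fold lower number from compound 1 to compound 3 (1.27 log units; beyond the scatter), both large steps, against the modest 4.4-fold higher number from compound 1 to compound 2 (0.65 log units; beyond the scatter). Compound 3 is therefore the strongest inhibitor of the three, and the two steps show that this gain holds against both nitrogen-only rings, not just against 1H-1,2,4-triazol-3-yl. The exchange from compound 2 to compound 3 replaces a ring with 1 hydrogen-bond donor by one with 0 donors and leaves the count of 2 acceptors unchanged, but nothing available here accounts for the size of the gain.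

The three compounds cannot separate the effect of the ring oxygen from that of losing the ring hydrogen on nitrogen, since the two changes arrive together in compound 3. A 1,3-thiazol-5-yl or a 1-methylimidazol-5-yl group at the same place would test whether the low number depends on that oxygen or extends to other rings without a hydrogen on nitrogen.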